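A few compounds are considered here, and "the series" means these few. Any claim that something is new, unique, unknown or untested is made for them only; others in the source may bear on it.

Measured so far:
compound 1, `S=C(N/N=C/c1ccc(Oc2ccccc2)cc1)Nc1ccc(Br)cc1`: 6.38
compound 2, `Cc1ccc(Oc2ccc(/C=N/NC(=S)Nc3ccc(Cl)cc3)cc2)cc1`: 5.97

Both numbers come from a physicochemical assay for lipophilicity, in phosphate buffer, measured as octanol-water partition, with a stated time of 24 h; a higher number here means a more lipophilic compound, a lower number a more polar compound. Of the two, compound 2 stands lower; its nearest neighbour, compound 1, sits higher by a gap that lies beyond the usual scatter of this assay. The two measured compounds differ from each other in more than one place, so their gap cannot be tied to any single exchange.

Compound 3, `Cc1ccc(Oc2ccc(/C=N/NC(=S)Nc3ccc(Br)cc3)cc2)cc1`, has not yet been measured in this assay. It differs from compound 2 in one place only: bromo in place of chloro on an aromatic carbon. For the measured compounds named here, no pair of measured compounds isolates this exchange, so its size has to be judged without a measured precedent.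

The step from compound 2 to compound 3 is expected to be small, a number 0.18 log units higher from compound 2 to compound 3 (within the scatter), upward if anywhere, and not clearly beyond the scatter of repeated measurements. On that basis compound 3 is estimated at 6.15, with a range from 5.85 to 6.45.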

Compound 3, partition coefficient: 6.17
Estimate against measurement, compound 3: 0.02 log units below; measured number inside the range.
By their numbers in this assay, from the lowest: compounds 2, 3 and 1 (each within the scatter of the next, the first and the last beyond it).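

In this assay, bromo in place of chloro on an aromatic carbon, para to a large group, now has a measured size in one matched pair: a number 0.20 log units higher from compound 2 to compound 3 (within the scatter), so chloro and bromo are not separated at this position in this pair. Compound 3 also isolates a second single exchange, methyl in place of hydrogen on an aromatic carbon, and this gives a number 0.21 log units lower from compound 1 to compound 3 (within the scatter), so that exchange likewise produces no separation in this assay on the bromo-bearing compounds. Nothing available bears on the origin of either step.

As far as these compounds go, each exchange rests on a single pair, so it remains open whether either would keep its size in another pair of the series, for instance whether methyl in place of hydrogen would read the same on the chloro-bearing compounds. Also open, from the compounds shown here alone, is whether a group of a different kind at the position now holding chloro or bromo, such as an amine or a carboxylic acid, would shift the number in this assay beyond the scatter.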